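This account rests on a few compounds, and the source may have more. Where it says the series, first, only, none or still open, it means among the compounds named here.

Measured so far:
compound 1 `Cn1ccnc1Cc1ccc2ccccc2c1O` — 3500 nM
compound 2 `COc1ccc(Cc2ccc3ccccc3c2O)cc1` — 75 nM

Compound 1 has the highest number of the two in an assay on RBL-1 cells with Polyunsaturated fatty acid 5-lipoxygenase (Rattus norvegicus) as the target; a higher number here means a weaker inhibitor, a lower number a stronger inhibitor; compound 2 sits far lower, beyond the scatter. Compound 3 `Oc1c(Cc2ccncc2)ccc2ccccc12` is not yet measured. It differs from compound 1 by pyridin-4-yl in place of 1-methyl-1H-imidazol-2-yl on a saturated chain carbon bound to an aromatic carbon. Within the data shown here, no measured pair shows this change, so the step of a 12-fold lower number from compound 1 to compound 3 (1.07 log units; beyond the scatter) is an expectation only: compound 3 is expected to move toward the lower number of compound 2 at 75 nM, since it too carries a six-membered aromatic ring. Compound 3 is estimated at 300 nM, within 60 nM to 1500 nM.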

Compound 3, half-maximal inhibitory concentration: 140 nM
Compound 3: middle estimate off by 2.1-fold (0.33 log units), on the high side; the range from low to high includes it.
By their numbers in this assay, from the lowest: compounds 2 and 3 (each within the scatter of the next); then compound 1.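

In this assay, pyridin-4-yl in place of 1-methyl-1H-imidazol-2-yl gives a 25-fold lower number from compound 1 to compound 3 (1.40 log units; beyond the scatter), the first measured sign that this place on the shared core responds strongly to the ring it carries. Compound 3 keeps a ring nitrogen yet lies within the scatter of compound 2, so a ring nitrogen alone does not hold the number high. No measurement here explains the step. Ring size and the count of ring hetero atoms change together, so their shares stay unseparated. From the compounds shown here alone, how an amine, a carboxylic acid or a longer chain would fare at this place remains open.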